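The compounds below may be only part of what the source reports. "The series", "measured", "known", "first", "only" and "open" are said of these compounds alone.

Compound 1 `O=C(O)c1c(O)c(F)c(F)c(F)c1F`: 0%
Compound 2 `O=C(O)c1cc(F)c(F)c(F)c1O`: 0%
Compound 3 `COC(=O)c1c(O)c(F)c(F)c(F)c1F`: 0%

All three were tested in a toxicity assay on the whole organism (strain CD-1) for cytotoxicity, with Mus musculus as the target, with a stated time of 14 days, at a dose of 300 mg/kg by the intraperitoneal route; a higher number here means a weaker effect of the compound at the dose given, a lower number a stronger effect. Among the compounds with values here, on these numbers compound 1 stands level with compounds 2 and 3: the step of no change at the digits printed from compound 1 to compound 2 (within the scatter) and the step of no change at the digits printed from compound 1 to compound 3 (within the scatter) both lie within the scatter, so no compound can be called stronger or weaker than another. Compound 4 `CC(=O)Oc1c(F)c(F)c(F)c(F)c1C(=O)O` has not yet been measured. It differs from compound 1 by acetyl in place of hydrogen on an oxygen on an aromatic ring. The measured step that bears most closely on this change, a small group placed on an oxygen, is no change at the digits printed from compound 1 to compound 3 (within the scatter); the step of no change at the digits printed from compound 1 to compound 2 (within the scatter) likewise shows no movement. A step of no size beyond the scatter is therefore expected for no change at the digits printed from compound 1 to compound 4 (within the scatter). Compound 4 is estimated at 0%, with a range from 0% to 10%.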

Compound 4, a percentage reported as activity, at one dose (the size of the read-out at that dose, not a potency): 0%
The estimate for compound 4 equals the measured number at the digits printed; measured number inside the range.
By their numbers in this assay, from the lowest: compounds 1, 2, 3 and 4 (each within the scatter of the next).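

In this assay, acetyl in place of hydrogen on an oxygen on an aromatic ring gives no change at the digits printed from compound 1 to compound 4 (within the scatter). This is the first change shown at the hydroxy group itself, and turning hydroxy into acetoxy leaves the read-out where it was. No measurement shown explains this result.

From the compounds shown here alone, whether a longer chain on this oxygen, or an amine in place of the hydroxy group, would read the same stays open. All four compounds sit at one level, so they offer no spread against which to rank any group.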